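The compounds below may be only part of what the source reports. "The series", "measured", "known", "first", "only" and "open" are said of these compounds alone.

Measured so far in a functional assay on NCI-H460 cells (Homo sapiens) for antiproliferative activity, read by CCK-8 assay, with a stated time of 72 h, tested at 8 uM; a higher number here means a stronger effect of the compound at the concentration tested, a lower number a weaker effect:
- compound 1 `Nc1ccccc1NC(=O)/C=C/c1ccc(Cn2cnc3c(Nc4cccc(Cl)c4)nc(Cl)nc32)cc1`: 29.4%
- compound 2 `Nc1ccccc1NC(=O)/C=C/c1ccc(Cn2cnc3c(NC4CCCCC4)nc(Cl)nc32)cc1`: 24.9%
- compound 3 `Nc1ccccc1NC(=O)c1ccc(Cn2cnc3c(Nc4cccc(OC(F)(F)F)c4)nc(Cl)nc32)cc1`: 62.4%

Compound 3 stands highest of the three; compound 1 is nearest and compound 2 furthest, both beyond the scatter. Among the compounds with values here, the only single-place step, a number 4.5 percentage points lower from compound 1 to compound 2 (within the scatter), concerns the group on the nitrogen and is within the scatter, so it does not bear on the change now in question.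

Compound 4 `Nc1ccccc1NC(=O)/C=C/c1ccc(Cn2cnc3c(Nc4cccc(OC(F)(F)F)c4)nc(Cl)nc32)cc1` differs from compound 3 by 2-((2-aminophenyl)carbamoyl)ethenyl in place of (2-aminophenyl)carbamoyl on an aromatic carbon. Within the data shown here, no measured step isolates this change. Both compounds that already carry 2-((2-aminophenyl)carbamoyl)ethenyl give lower numbers than compound 3, but each also differs at the nitrogen, so the comparison is indirect. A downward step a number 17.4 percentage points lower from compound 3 to compound 4 (beyond the scatter) is expected, with wide uncertainty. Compound 4 is estimated at 45%, range 25% to 65%.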

Compound 4, a percentage reported as inhibition, at one concentration (the size of the read-out at that concentration, not a potency): 66.7%
Estimate against measurement, compound 4: 21.7 percentage points below; measured number outside the range, above it.
By their numbers in this assay, from the lowest: compounds 2 and 1 (each within the scatter of the next); then compounds 3 and 4 (each within the scatter of the next).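

In this assay, with 3-(trifluoromethoxy)phenyl held on the nitrogen, 2-((2-aminophenyl)carbamoyl)ethenyl in place of (2-aminophenyl)carbamoyl on this aromatic carbon gives a number 4.3 percentage points higher from compound 3 to compound 4 (within the scatter) and so leaves the read-out unchanged. With that ethenyl group held, the large steps lie at the nitrogen substituent: a number 37.3 percentage points higher from compound 1 to compound 4 (beyond the scatter) for trifluoromethoxy in place of chloro, and a number 41.8 percentage points higher from compound 2 to compound 4 (beyond the scatter) for 3-(trifluoromethoxy)phenyl in place of cyclohexyl. No evidence on hand accounts for these steps.

Open, on these data alone, is whether a methoxy or trifluoromethyl group in place of trifluoromethoxy would keep the higher read-out. Also open, as far as these compounds go, is whether a longer chain at this aromatic carbon would leave it unchanged.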